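Cytotoxicity notes on a small amide series

The compounds below may be only part of what the source reports. "The series", "measured", "known", "first", "only" and "open" are said of these compounds alone.

Measured so far:
compound 1, `CC(Sc1nnc(-c2ccncc2)s1)C(=O)Nc1ccccc1`: > 50000 nM
compound 2, `CC(Sc1nnc(-c2ccncc2)s1)C(=O)NCc1ccccc1`: > 50000 nM
compound 3, `CC(CSc1nnc(-c2ccncc2)s1)C(=O)NCc1ccccc1`: > 50000 nM

In an ADME assay on BHK-21 cells (Mesocricetus auratus) for cytotoxicity, with a stated time of 3 days (on this read-out lower numbers stand for higher toxicity in this test and higher numbers for lower toxicity in this test), compound 1 gives > 50000 nM, which is a limit of the assay and not a number. In this assay compound 2 gives > 50000 nM, again only a limit. In this assay compound 3 gives > 50000 nM, also a limit. The change from compound 2 to compound 1 is phenyl in place of benzyl on an amide-type nitrogen. The step that the two limits leave unreadable from compound 2 to compound 1 cannot be sized because of the limit of > 50000 nM in this assay, at which 3 of the 3 values shown sit.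

Compound 4, `CC(CSc1nnc(-c2ccncc2)s1)C(=O)Nc1ccccc1`, is not yet measured. For the measured compounds named here, it differs from compound 3 by phenyl in place of benzyl on an amide-type nitrogen, which is the same change as the one from compound 2 to compound 1, made at the same place. How the core of compound 3 differs from the core of compound 2 is not broken down here.

Going by the values given here, for compound 4 the step that the limit leaves unreadable from compound 3 to compound 4 in this assay is expected to be unreadable in the same way, since the one earlier instance of this change left both values at the limit. The expectation rests on compound 1 sitting at > 50000 nM and on compound 3 sitting at > 50000 nM. Compound 4 is therefore expected to give 80000 nM in this assay, most likely reported as a limit rather than a number.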

Compound 4, half-maximal cytotoxic concentration: > 50000 nM
Compound 4 ended at the assay's limit; the forecaster's own chance of this, stated with the estimate: 85%; the middle value is on the limit's open side.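

No size can be read for the step from compound 3 to compound 4, nor for the earlier step from compound 2 to compound 1, because each of these values is a limit and not a number: the limit of > 50000 nM in this assay, at which 4 of the 4 values shown sit.

The compounds shown leave open whether phenyl in place of benzyl on an amide-type nitrogen changes the read-out in this assay at all, and what a compound of this series giving an actual number there would look like.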